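The source may report more compounds than this note shows. Statements on the series, on what has been measured and on what is new or still open speak of the compounds shown alone.

Series notes. The shared core of compound 1 `CCCCc1ccc(NS(=O)(=O)c2ccc(N3CCNC3=O)cc2)cc1` carries a butyl group on the aniline ring, and in a functional assay on M21 cells (Homo sapiens) for antiproliferative activity, read by sulforhodamine B assay, with a stated time of 48 h (a higher number here means a weaker inhibitor, a lower number a stronger inhibitor), compound 1 gives 450 nM. Among the three numbers so far, compound 1 stands highest. Its nearest neighbour is compound 3 `O=C1NCCN1c1ccc(S(=O)(=O)Nc2ccc(OC(F)F)cc2)cc1`, which gives 410 nM in this assay; the single-point change here is a 1.1-fold lower number from compound 1 to compound 3 (0.04 log units; within the scatter). The furthest is compound 2 `Cc1ccc(NS(=O)(=O)c2ccc(N3CCNC3=O)cc2)cc1C`, which gives 94 nM in this assay. Compound 4 `O=C1NCCN1c1ccc(S(=O)(=O)Nc2ccc(Br)cc2)cc1` differs from compound 1 by bromo in place of butyl on an aromatic carbon. Within the data shown here, the only measured step that bears on this change is the one from compound 1 to compound 3, which is within the scatter. On that basis a step of at most modest size is expected for compound 4, probably toward a lower number but not clearly beyond the scatter, so the estimate for compound 4 is 300 nM, with a range from 100 nM to 900 nM, and the expected step is a 1.5-fold lower number from compound 1 to compound 4 (0.18 log units; within the scatter).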

Compound 4, half-maximal inhibitory concentration: 130 nM
Compound 4: the middle estimate sits 2.3-fold (0.36 log units) above what was measured, within the range that was stated.
By their numbers in this assay, from the lowest: compounds 2 and 4 (each within the scatter of the next); then compounds 3 and 1 (each within the scatter of the next).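

At this position on the aromatic carbon, the choice of group does shift the number in this assay: bromo in place of butyl gives a 3.5-fold lower number from compound 1 to compound 4 (0.54 log units; beyond the scatter), and bromo in place of difluoromethoxy gives a 3.2-fold lower number from compound 3 to compound 4 (0.50 log units; beyond the scatter), whereas the earlier step between those two groups stayed within the scatter. The 4-bromophenyl group in place of 3,4-dimethylphenyl gives a 1.4-fold higher number from compound 2 to compound 4 (0.14 log units; within the scatter), so these two stay level. No measured evidence bears on why bromo separates from butyl and difluoromethoxy.

Open, on these data alone, is whether chloro, an amine or a carboxylic acid here would track with bromo or with butyl.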